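This account rests on a few compounds, and the source may have more. Where it says the series, first, only, none or still open, it means among the compounds named here.

Notes on the step from compound 3 to compound 4. In an ADME assay on Huh-7 cells (Homo sapiens) for cytotoxicity, with a stated time of 72 h (a higher number here means that more compound is tolerated, a lower number that less compound is tolerated), compound 3 `CS(=O)(=O)Nc1ccc2c(c1)S(=O)(=O)N=C(c1c(O)c(-c3cccs3)nn(CC3(C(F)(F)F)CC3)c1=O)N2` gives > 1000 nM, which is a limit and not a number. Compound 3 shares (the limit of > 1000 nM in this assay, at which 2 of the 3 values shown sit). Compound 1 `CS(=O)(=O)Nc1ccc2c(c1)S(=O)(=O)N=C(c1c(O)c(-c3cccs3)nn(CC3CCC3)c1=O)N2` gives > 1000 nM, also a limit. Compound 2 `CCCC(C)n1nc(-c2cccs2)c(O)c(C2=NS(=O)(=O)c3cc(NS(C)(=O)=O)ccc3N2)c1=O` gives > 33000 nM, again a limit.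

Compound 4 `CS(=O)(=O)Nc1ccc2c(c1)S(=O)(=O)N=C(c1c(O)c(-c3cccs3)nn(Cc3ccccn3)c1=O)N2` is still to be measured in this assay. It carries pyridin-2-yl in place of 1-(trifluoromethyl)cyclopropyl on a saturated chain carbon bound to an aromatic nitrogen. Cut one bond further out, this reads (1-(trifluoromethyl)cyclopropyl)methyl to (pyridin-2-yl)methyl.

Among the measured compounds shown here, three measured steps bear on this change: a step that the two limits leave unreadable from compound 1 to compound 3, a step that the two limits leave unreadable from compound 2 to compound 3 and a step that the two limits leave unreadable from compound 1 to compound 2. All three alter the group on the aromatic nitrogen, and none has a readable size. No pyridine-bearing comparison is available in this set.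

For the measured compounds named here, no direction can therefore be drawn for this assay, and the expectation is only that compound 4 remains well tolerated, like the other three. This expectation rests on compound 3, whose > 1000 nM is a limit. The estimated step, a step that the limit leaves unreadable from compound 3 to compound 4, starts from that limit, so its size is only loosely expected. Compound 4 is expected at 15000 nM, with an estimated range from 2000 nM to 50000 nM.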

Compound 4, half-maximal cytotoxic concentration: > 1000 nM
Compound 4 was reported as a limit; the forecaster's own chance of this, stated with the estimate: 85%; the middle value lies beyond the limit too.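

In this assay compound 4 gives > 1000 nM, which is a limit and not a number. Among the compounds shown here, compound 1, compound 2 and compound 3 are also reported as limits, and no step to compound 4 can be read. The compounds shown leave open whether the group on the aromatic nitrogen changes tolerance at all.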